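This account rests on a few compounds, and the source may have more. Where it says the series, first, only, none or still open, it means among the compounds named here.

Three compounds share one core and differ only in the group on the outer ring. In a functional assay for agonist activity at growth hormone secretagogue receptor type 1 (Homo sapiens), read by FLIPR (a higher number here means that more compound is needed for the effect, a lower number that less compound is needed), compound 1 `COc1ccc(N2C[C@@H](C)N[C@@H](C)C2)cc1NS(=O)(=O)c1ccc(-c2ccccc2)cc1` gives 6.31 nM, compound 2 `COc1ccc(N2C[C@@H](C)N[C@@H](C)C2)cc1NS(=O)(=O)c1ccc(-c2cc(Cl)ccc2F)cc1` gives 0.501 nM, and compound 3 `COc1ccc(N2C[C@@H](C)N[C@@H](C)C2)cc1NS(=O)(=O)c1ccc(N2CCCC2=O)cc1` gives 39.8 nM, the highest of the three. The steps were a 6.3-fold higher number from compound 1 to compound 3 (0.80 log units; beyond the scatter) and a 79-fold higher number from compound 2 to compound 3 (1.90 log units; beyond the scatter). Compound 4 `COc1ccc(N2C[C@@H](C)N[C@@H](C)C2)cc1NS(=O)(=O)c1ccc(-c2ccc(C)o2)cc1` carries the change (5-methylfuran-2-yl in place of 2-oxopyrrolidin-1-yl on an aromatic carbon), so the group that raised the number in both steps is replaced by one five-membered aromatic ring, closer in kind to the groups of compounds 1 and 2. A step of a 5.0-fold lower number from compound 3 to compound 4 (0.70 log units; beyond the scatter) is therefore expected, back toward compound 1. Compound 4 is estimated at 8 nM, likely between 2 nM and 30 nM.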

Compound 4, half-maximal effective concentration: 0.794 nM
Compound 4: the middle estimate sits 10-fold (1.00 log units) above what was measured, and the stated range ends above it.
By their numbers in this assay, from the lowest: compounds 2 and 4 (each within the scatter of the next); then compound 1; then compound 3.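

Replacing 2-oxopyrrolidin-1-yl with 5-methylfuran-2-yl keeps the heavy-atom and hydrogen-bond acceptor counts the same, yet this assay shows a 50-fold lower number from compound 3 to compound 4 (1.70 log units; beyond the scatter), so this position distinguishes between two five-membered rings of equal heavy-atom count. A six-membered aromatic ring is also not required here: 5-methylfuran-2-yl gives a 7.9-fold lower number from compound 1 to compound 4 (0.90 log units; beyond the scatter) against phenyl, and a 1.6-fold higher number from compound 2 to compound 4 (0.20 log units; within the scatter) against 5-chloro-2-fluorophenyl. No evidence is available to explain these differences. The compounds shown leave open what the methyl group on the furan contributes, and whether an unsubstituted furan-2-yl, a thiophene or a saturated tetrahydrofuran ring would behave alike.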